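This account rests on a few compounds, and the source may have more. Where it says the series, first, only, none or still open, it means among the compounds named here.

Compound 2 `O=C(Nc1nc2ccccc2s1)c1cn(-c2ccccc2)nc1-c1ccc(F)cc1` gives the higher of the two numbers recorded so far: in a functional assay on PC-3 cells (Homo sapiens) for cytotoxicity, read by MTT assay, with a stated time of 72 h (on this read-out lower numbers stand for stronger inhibition and higher numbers for weaker inhibition), compound 2 gives 7130 nM. Compound 1 `O=C(Nc1nc2ccc(F)cc2s1)c1cn(-c2ccccc2)nc1-c1ccccc1`, which carries its single fluoro elsewhere, gives in this assay 3250 nM, a gap beyond the usual scatter. Compound 3 `O=C(Nc1nc2ccc(F)cc2s1)c1cn(-c2ccccc2)nc1-c1ccc(F)cc1` differs from compound 2 by fluoro in place of hydrogen on an aromatic carbon. Going by the values given here, no measured pair shows this exact change. The expected step of a 1.6-fold lower number from compound 2 to compound 3 (0.20 log units; within the scatter) is therefore modest, toward a lower number, and may stay within the scatter. Compound 3 is estimated at 4500 nM, between 1800 nM and 11000 nM.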

Compound 3, half-maximal inhibitory concentration: 5260 nM
Beside the measured number, compound 3's estimate is 1.2-fold (0.07 log units) below it; the measured number falls inside the stated range.
By their numbers in this assay, from the lowest: compounds 1, 3 and 2 (each within the scatter of the next, the first and the last beyond it).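

In this assay, going by these compounds alone, going from 1,3-benzothiazol-2-yl to 6-fluoro-1,3-benzothiazol-2-yl gives a 1.4-fold lower number from compound 2 to compound 3 (0.13 log units; within the scatter), the first reading of fluoro in place of hydrogen at this position. The same kind of change on the other fluorinated ring gives a 1.6-fold higher number from compound 1 to compound 3 (0.21 log units; within the scatter), so neither single fluoro step moves the number beyond the scatter. Nothing available explains these numbers. As far as these compounds go, whether a different group at this position, such as a methoxy group, chloro or an amine, would shift the number beyond the scatter stays open.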